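Hydrazide Sulfonamides on Lung Cancer Cells: Extending the Series

This account rests on a few compounds, and the source may have more. Where it says the series, first, only, none or still open, it means among the compounds named here.

Of the compounds shown here, three have so far been measured in a functional assay on A549 cells (Homo sapiens) for antiproliferative activity, read by MTT assay, with a stated time of 24 h; on this read-out higher numbers stand for weaker inhibition and lower numbers for stronger inhibition. Compound 1 `O=C(NNc1ccccc1Cl)c1ccc(NS(=O)(=O)c2cnc(O)nc2O)cc1` gives 3340 nM. Compound 2 `O=C(NNc1ccccc1F)c1cccc(NS(=O)(=O)c2cnc(O)nc2O)c1` gives 11100 nM. Compound 3 `O=C(NNc1ccccc1Cl)c1ccccc1NS(=O)(=O)c1cnc(O)nc1O` gives 5480 nM. Among these three numbers compound 3 holds the second highest place; its nearest neighbour is compound 1, whose number lies within the scatter of its own, and its furthest is compound 2, whose number stands beyond the scatter above it.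

Compound 4 `O=C(NNC(=O)c1ccccc1NS(=O)(=O)c1cnc(O)nc1O)c1ccc(F)cc1` differs from compound 3 in one place: (4-fluorophenyl)carbonyl in place of 2-chlorophenyl on an amine nitrogen. Among the measured compounds shown here, no pair of measured compounds traces this same change, so its effect cannot be read from the numbers in hand. The amine nitrogen whose other neighbour is the amide-type nitrogen now carries a (4-fluorophenyl)carbonyl group, which brings one more hydrogen-bond acceptor and one double bond outside aromatic rings, where the 2-chlorophenyl brought neither. With nothing in the data to anchor this change, the step of a 1.3-fold higher number from compound 3 to compound 4 (0.11 log units; within the scatter) is expected to be small, leaning toward a higher number, but not clearly beyond the scatter. Compound 4 is therefore estimated at 7000 nM, with a range from 2500 nM to 20000 nM.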

Compound 4, half-maximal inhibitory concentration: > 20000 nM
Compound 4 gave a limit, no number (the forecaster's own chance of this, stated with the estimate: 10%); at least 2.8-fold (0.45 log units) between middle value and limit.
By their numbers in this assay, from the lowest: compounds 1 and 3 (each within the scatter of the next); then compound 2. At a limit, above all of these: compound 4.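

Compound 1, compound 2 and compound 3 all carry a halogen-substituted phenyl ring directly on this amine nitrogen, so they gave no view of what a different kind of group does there. In this assay, among the compounds shown here, placing (4-fluorophenyl)carbonyl in place of 2-chlorophenyl on the amine nitrogen whose other neighbour is the amide-type nitrogen gives an at least 3.6-fold higher number from compound 3 to compound 4 (0.56 log units; beyond the scatter), the first step that can be read and one that lies beyond the scatter, so this position does not tolerate every change and the new group weakens the inhibition. Compound 4 stands at a limit of the assay and not at a number, and it is the only compound of the four to do so: the limit of > 20000 nM in this assay, at which 1 of the 4 values shown sits.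

The step changes the carbonyl, the halogen and the place of the halogen on the ring all at once, and these cannot be told apart from the compounds shown. A (2-chlorophenyl)carbonyl group on this nitrogen would separate the carbonyl from the halogen, while an acetyl group or a short alkyl chain would show whether the aromatic ring matters at this position at all.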